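The compounds below may be only part of what the source reports. "The series", "measured", "known", "first", "only" and "open" are said of these compounds alone.

Measured so far in an ADME assay on Vero cells (Chlorocebus sabaeus) for cytotoxicity, read by MTT assay, with a stated time of 96 h; a higher number here means that more compound is tolerated, a lower number that less compound is tolerated:
Compound 1 `C/C(=N\NC(N)=S)c1ccc2[nH]c(-c3ccccc3)nc2c1`: > 100000 nM
Compound 2 `C/C(=N\NC(N)=S)c1ccc2[nH]c(-c3ccc(Cl)cc3)nc2c1`: > 100000 nM
Compound 3 `C/C(=N\NC(N)=O)c1ccc2[nH]c(-c3ccoc3)nc2c1`: > 100000 nM

Each of these entries is a limit of the assay and not a number. Compound 3 therefore has only its limit of > 100000 nM. The measured compounds all sit at one place: the limit of > 100000 nM in this assay, at which 3 of the 3 values shown sit.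

Compound 4 `C/C(=N\NC(N)=S)c1ccc2[nH]c(-c3ccoc3)nc2c1` keeps the core of compound 3 and changes one group, on an amine nitrogen: a group of 3 heavy atoms (1 carbon, 1 nitrogen, 1 sulfur; no ring) in place of a group of 3 heavy atoms (1 carbon, 1 nitrogen, 1 oxygen; no ring), on an amine nitrogen. The sulfur-bearing group that enters is already present in two measured compounds. Compound 1 carries it and gives > 100000 nM, which is a limit. Compound 2 carries it as well and gives > 100000 nM, again a limit. Among the compounds with values here, the one measured step is a different change, a step that the two limits leave unreadable from compound 1 to compound 2, so it offers no size to borrow.

No step beyond the scatter is therefore expected in this assay, and a further limit is the likeliest report. The estimated step is a number no higher from compound 3 to compound 4 (the limit leaves the size open). Compound 4 is expected at 100000 nM, with an estimated range of 30000 nM to 150000 nM.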

Compound 4, half-maximal cytotoxic concentration: 100000 nM
Compound 4: the middle estimate sits on the measured number at the digits printed, within the range that was stated.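

In this assay, within the data shown here, compound 4 gives 100000 nM, a plain number and the only value in this set that is not a limit, and the sulfur-bearing group in place of carbamoyl on the amine nitrogen gives a number no higher from compound 3 to compound 4 (the limit leaves the size open). Furan-3-yl in place of 4-chlorophenyl gives a number no higher from compound 2 to compound 4 (the limit leaves the size open). Furan-3-yl in place of phenyl gives a number no higher from compound 1 to compound 4 (the limit leaves the size open). None of these three steps can be read, so none of these changes has a size that can be stated. Compound 4 therefore adds one exact reading to a set whose other values all sit at one place: the limit of > 100000 nM in this assay, at which 3 of the 4 values shown sit.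

From the compounds shown here alone, it remains open whether a different group on this amine nitrogen, such as a methyl group or a longer chain, would lower the tolerated concentration. The same question stands for a ring carrying an amine or a carboxylic acid in place of furan-3-yl.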